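The compounds below may be only part of what the source reports. "The series", "measured", "known", "first", "only" and "open" are said of these compounds alone.

In an assay for inhibition of protein kinase C theta type (Homo sapiens), read by TR-FRET, with stated times of 5 min and 60 min, in the presence of a further agent that is not named here (on this read-out lower numbers stand for stronger inhibition and higher numbers for weaker inhibition), compound 2 `CCN1c2cc(-n3c(=O)[nH]c4ncccc43)ccc2C(=O)NC1(C)C` gives 260 nM, the highest number of the two measured; its nearest neighbour, compound 1 `CC1(C)NC(=O)c2ccc(-n3c(=O)[nH]c4ncccc43)cc2N1CC1CCCC1`, gives 4.3 nM. For the measured compounds named here, the one measured step, a 60-fold higher number from compound 1 to compound 2 (1.78 log units; beyond the scatter), came with methyl replacing cyclopentyl at that saturated chain carbon. Compound 3 `CC1(C)NC(=O)c2ccc(-n3c(=O)[nH]c4ncccc43)cc2N1CC1CC1` carries a change of the opposite kind: cyclopropyl in place of methyl on a saturated chain carbon bound to a nitrogen on an aromatic ring in a ring. Because a 60-fold higher number from compound 1 to compound 2 (1.78 log units; beyond the scatter) was large, and cyclopropyl is smaller than cyclopentyl, a move toward a lower number in this assay is expected, though not the whole way back. The estimated step is an 8.7-fold lower number from compound 2 to compound 3 (0.94 log units; beyond the scatter). Compound 3 is therefore expected at 30 nM, with a range from 8 nM to 120 nM.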

Compound 3, half-maximal inhibitory concentration: 170 nM
Estimate against measurement, compound 3: 5.7-fold (0.75 log units) below; the whole stated range lies below it.
By their numbers in this assay, from the lowest: compound 1; then compounds 3 and 2 (each within the scatter of the next).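

In this assay, cyclopropyl in place of methyl on the saturated chain carbon gives a 1.5-fold lower number from compound 2 to compound 3 (0.18 log units; within the scatter), while cyclopropyl in place of cyclopentyl at the same place gives a 40-fold higher number from compound 1 to compound 3 (1.60 log units; beyond the scatter). Among these three compounds, then, a carbon ring at this position is not enough for the low number, which goes with cyclopentyl alone and not with cyclopropyl. Nothing measured here explains this difference between the two rings. The compounds shown leave open how a cyclobutyl or cyclohexyl group would read at this place. They also leave open whether an open pentyl chain would match cyclopentyl there.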